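Aryl swap on the acylhydrazone series: compound 2 to compound 3

The compounds below may be only part of what the source reports. "The series", "measured", "known", "first", "only" and "open" are said of these compounds alone.

Among the compounds with values here, compound 2 `C/C(=N\NC(=O)c1ccc(CSc2nc(C)cc(C)n2)cc1)c1ccc(F)cc1` is the one member of the series with a numerical read-out: in a functional assay on BCG823 cells (Homo sapiens) for inhibition, read by MTT assay, with a stated time of 72 h (on this read-out lower numbers stand for stronger inhibition and higher numbers for weaker inhibition), compound 2 gives 3.88 ug/mL. Compound 1 `C/C(=N\NC(=O)c1ccc(CSc2nc3ccccc3s2)cc1)c1ccc(C)c([N+](=O)[O-])c1` in this assay gives > 80 ug/mL, which is a limit of the assay and not a number. Within the data shown here, compound 1 carries the same 4-methyl-3-nitrophenyl group that enters in compound 3, but it differs from compound 2 in a second place as well, so no single step between measured compounds can be drawn; the two values show only that compound 2 gives a number where compound 1 stops at the limit. Compound 3 `C/C(=N\NC(=O)c1ccc(CSc2nc(C)cc(C)n2)cc1)c1ccc(C)c([N+](=O)[O-])c1` differs from compound 2 by 4-methyl-3-nitrophenyl in place of 4-fluorophenyl on a carbon with a double bond to nitrogen. Among the measured compounds shown here, with no measured step to lean on, the expected step from compound 2 to compound 3, a 6.4-fold higher number from compound 2 to compound 3 (0.81 log units; beyond the scatter), is a loss of inhibition beyond the usual scatter, its size uncertain. The lean toward weaker inhibition rests on (the limit of > 80 ug/mL in this assay, at which 1 of the 2 values shown sits), where compound 1 with the same entering group sits. Compound 3 is therefore estimated at 25 ug/mL, with a range from 6 ug/mL to 80 ug/mL, and a real chance that only a limit is reported.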

Compound 3, half-maximal inhibitory concentration: > 80 ug/mL
Compound 3 was reported as a limit; the forecaster's own chance of this, stated with the estimate: 35%; at least 3.2-fold (0.50 log units) between middle value and limit.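

In this assay, this position now has its first readable single-place step: 4-methyl-3-nitrophenyl in place of 4-fluorophenyl on a carbon with a double bond to nitrogen gives an at least 20-fold higher number from compound 2 to compound 3 (1.31 log units; beyond the scatter), a large step with the pyrimidine side of the molecule unchanged. Compound 3 gives > 80 ug/mL, which is a limit of the assay and not a number. The step from compound 1 to compound 3, 4,6-dimethylpyrimidin-2-yl in place of 1,3-benzothiazol-2-yl on a sulfur, cannot be read, so the group on the sulfur gains no ranking, and 4-methyl-3-nitrophenyl now sits at the limit with both groups there, while the only numerical read-out belongs to compound 2 with 4-fluorophenyl: the limit of > 80 ug/mL in this assay, at which 2 of the 3 values shown sit.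

Open is whether the methyl or the nitro of the entering group goes with the loss, as the compounds shown hold the two only together. Also open, from the compounds shown here alone, is how a morpholine or a carboxylic acid at this place would read in this assay, and whether 4-fluorophenyl still gives a number with 1,3-benzothiazol-2-yl on the sulfur.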